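The source may report more compounds than this note shows. Statements on the series, on what has been measured and on what is new or still open speak of the compounds shown alone.

Compound 2 `COc1ccc(-c2nn(-c3ccccc3)cc2C(=O)Nc2nc3ccc(Cl)cc3s2)cc1` and compound 1 `COc1ccc(-c2nn(-c3ccccc3)cc2C(=O)Nc2nc3ccccc3s2)cc1` share one core and differ only at a single aromatic carbon on the fused ring system, where compound 2 carries a chloro group and compound 1 a hydrogen. In a functional assay on PC-3 cells (Homo sapiens) for cytotoxicity, read by MTT assay, with a stated time of 72 h (on this read-out higher numbers stand for weaker inhibition and lower numbers for stronger inhibition), compound 1 gives 6670 nM, and in this assay compound 2 gives 6510 nM. The step of a 1.0-fold lower number from compound 1 to compound 2 (0.01 log units; within the scatter) shows that swapping hydrogen for chloro at this position left the number essentially unchanged, so compound 2 cannot be told apart from compound 1 on these two measurements.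

Compound 3 `COc1ccc(-c2nn(-c3ccccc3)cc2C(=O)Nc2nc3ccc(OC)cc3s2)cc1` is the next member, obtained from compound 2 by the change (methoxy in place of chloro on an aromatic carbon). Going by the values given here, the only step measured so far, a 1.0-fold lower number from compound 1 to compound 2 (0.01 log units; within the scatter), touches this same position and was within the scatter; no measured step involves a methoxy group. On that basis the expected step of a 1.0-fold lower number from compound 2 to compound 3 (0.00 log units; within the scatter) in this assay is none beyond the scatter, in no firm direction. Compound 3 is therefore estimated to give about 6500 nM in this assay, most likely falling between 3000 nM and 14000 nM.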

Compound 3, half-maximal inhibitory concentration: 13500 nM
Compound 3: middle estimate off by 2.1-fold (0.32 log units), on the low side, and the stated range covers the measured number.
By their numbers in this assay, from the lowest: compounds 2 and 1 (each within the scatter of the next); then compound 3.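

Going by these compounds alone, at this position, on an aromatic carbon of a six-membered aromatic ring, the earlier pair suggested that the substituent hardly mattered, but methoxy gives the first step beyond the scatter in this assay (a 2.1-fold higher number from compound 2 to compound 3 (0.32 log units; beyond the scatter)). Measured against the unsubstituted compound, the result is much the same (a 2.0-fold higher number from compound 1 to compound 3 (0.31 log units; beyond the scatter)), so compound 3 shows weaker inhibition than both earlier compounds, though the change is modest and compound 1 and compound 2 remain within the scatter of each other. The position therefore responds to at least one change, and methoxy is the only group shown that moves the number, in the direction of weaker inhibition; nothing available here accounts for this difference.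

The three compounds leave open whether any group at this position can bring the number lower than in compound 1 and compound 2, or whether the shift seen with methoxy grows with a longer chain such as ethoxy. As far as these compounds go, how an amine or a carboxylic acid at the same carbon would behave also remains open, as does whether the modest step holds beyond these PC-3 cells.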